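The source may hold more compounds than are shown below. What is called first, only, known or untested is meant among the compounds shown, and "the series" means these compounds.

Compound 1 `C=C1C[C@]23C[C@@]1(O)CC[C@H]2c1ccc(O)c(C)c1[C@@H]3Cn1cc(-c2ccccc2)nn1` pairs a shared core with a plain phenyl group. In a functional assay on SW480 cells (Homo sapiens) for cytotoxicity, read by MTT assay, with a stated time of 4 days (a lower number here means a stronger inhibitor, a higher number a weaker inhibitor), compound 1 reaches only a limit of the assay, > 20000 nM. Compound 2 `C=C1C[C@]23C[C@@]1(O)CC[C@H]2c1ccc(O)c(C)c1[C@@H]3Cn1cc(-c2ccc(OC)cc2)nn1` keeps that core and carries a methoxy on the phenyl ring. In this assay compound 2 likewise reaches only a limit, > 20000 nM. The step from compound 1 to compound 2 is a step that the two limits leave unreadable from compound 1 to compound 2. Within the data shown here, both measured values sit at the same point, (the limit of > 20000 nM in this assay, at which 2 of the 2 values shown sit), so compound 2 stands at the limit rather than at a number, and no compound here is known to be stronger or weaker than another.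

Compound 3 `C=C1C[C@]23C[C@@]1(O)CC[C@H]2c1ccc(O)c(C)c1[C@@H]3Cn1cc(-c2ccc(C)cc2)nn1` is the next step: methyl in place of methoxy on an aromatic carbon. Among the measured compounds shown here, the one measured step, from compound 1 to compound 2, was unreadable, so no measured step gives the size or direction of this change. For the measured compounds named here, the only guide is that every value here is a limit. Compound 3 is therefore expected to give 30000 nM, within a range from 10000 nM to 100000 nM, most likely again as a limit. The expected step is a step that the limit leaves unreadable from compound 2 to compound 3, no more than the scatter.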

Compound 3, half-maximal inhibitory concentration: > 20000 nM
Compound 3: only a limit was reported; the forecaster's own chance of this, stated with the estimate: 85%; the middle value is on the limit's open side.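

In this assay compound 3 reaches > 20000 nM as only a limit of the assay. The steps among compound 1, compound 2 and compound 3 therefore cannot be read, and none of the three can be ranked against another: the limit of > 20000 nM in this assay, at which 3 of the 3 values shown sit. These compounds leave open whether any change on the phenyl ring alters cytotoxicity, and how far each true value lies past the limit.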